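A few compounds are considered here, and "the series" means these few. Any claim that something is new, unique, unknown or untested is made for them only; others in the source may bear on it.

Of the compounds shown here, three sharing one core have been measured in a functional assay on SW-620 cells (Homo sapiens); a lower number here means a stronger inhibitor of growth, a higher number a weaker inhibitor of growth: compound 1 (`O=S(=O)(/C=C/c1ccc(F)cc1)Cc1ccc(Nc2ncnc3ccccc23)cc1`), compound 2 (`O=S(=O)(/C=C/c1ccc(Cl)cc1Cl)Cc1ccc(Nc2ncnc3ccccc23)cc1`) and compound 3 (`O=S(=O)(/C=C/c1ccc(F)cc1F)Cc1ccc(Nc2ncnc3ccccc23)cc1`). Compound 1 gives 100000 nM, while compound 2 gives 14000 nM and is the strongest inhibitor of the three. Compound 3 gives 86000 nM, which lies within the scatter of compound 1 and well short of compound 2.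

Compound 4 (`O=S(=O)(/C=C/c1ccc(O)cc1)Cc1ccc(Nc2ncnc3ccccc23)cc1`) has yet to be measured. It carries 4-hydroxyphenyl in place of 2,4-difluorophenyl on a double-bonded chain carbon bound to a double-bonded chain carbon.

Among the compounds with values here, no measured compound carries 4-hydroxyphenyl, so the evidence is indirect. Three measured steps change the group at this place. Two were modest, a 7.1-fold lower number from compound 1 to compound 2 (0.85 log units; beyond the scatter) and a 6.1-fold higher number from compound 2 to compound 3 (0.79 log units; beyond the scatter), and the third was a 1.2-fold lower number from compound 1 to compound 3 (0.07 log units; within the scatter). These steps suggest that this place can move the number, though only compound 2 has left the range shared by the other two. For this assay, no step beyond the scatter is therefore expected, with a slight lean towards a lower number. The estimated step is a 1.7-fold lower number from compound 3 to compound 4 (0.24 log units; within the scatter). The expected value for compound 4 is 50000 nM, with an estimated range of 14000 nM to 100000 nM.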

Compound 4, concentration for 50% growth inhibition: 100000 nM
Estimate against measurement, compound 4: 2.0-fold (0.30 log units) below; measured number inside the range.
By their numbers in this assay, from the lowest: compound 2; then compounds 3, 1 and 4 (each within the scatter of the next).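

In this assay, 4-hydroxyphenyl in place of 2,4-difluorophenyl gives a 1.2-fold higher number from compound 3 to compound 4 (0.07 log units; within the scatter), and hydroxy in place of fluoro on an aromatic carbon gives no change at the digits printed from compound 1 to compound 4 (within the scatter), so a group with a hydrogen-bond donor and acceptor behaves here like the two fluorinated groups, which have neither. Only 2,4-dichlorophenyl stands apart, with a 7.1-fold higher number from compound 2 to compound 4 (0.85 log units; beyond the scatter), which leaves compound 2 the strongest inhibitor of the four and shows that a change of ring substituent at this place does not by itself move the number beyond the scatter. Nothing shown here gives a measured reason for this pattern.

On these data alone, what stays open is whether a single chloro on the ring would match 2,4-dichlorophenyl or fall in with the other groups, and whether bromo, methoxy or a carboxylic acid at this place would follow compound 2 or the remaining three. As far as these compounds go, the shared core is the same in all four compounds, so it also remains unknown whether this pattern would hold with an added amine on the core.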